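A few compounds are considered here, and "the series" means these few. Any claim that something is new, unique, unknown or untested is made for them only; others in the source may bear on it.

Compound 1 `COc1cc(C(=O)c2cn(-c3ccccc3)cc2-c2ccc(N)cc2)cc(OC)c1OC`: 9 nM
Compound 2 `COc1ccccc1-n1cc(C(=O)c2cc(OC)c(OC)c(OC)c2)c(-c2ccccc2)c1`: 150 nM

Among the compounds with values here, in a functional assay on MCF7 cells (Homo sapiens) for cytotoxicity, read by MTT assay, with a stated time of 96 h (a lower number here means a stronger inhibitor, a higher number a weaker inhibitor), compound 1 gives 9 nM, the lowest of the two numbers measured so far. Within the data shown here, the only other measured compound, compound 2, gives 150 nM, a gap beyond the scatter.

Compound 3 `COc1cc(C(=O)c2cn(-c3ccccc3)cc2-c2ccccc2Cl)cc(OC)c1OC` has not yet been measured. Relative to compound 1, it has 2-chlorophenyl in place of 4-aminophenyl on an aromatic carbon. This carbon belongs to a five-membered aromatic ring with 1 nitrogen and lies next to the ring atom that bears a large group.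

Among the measured compounds shown here, no measured pair shows this change alone, so the expectation is uncertain. With compound 1 at 9 nM, the lower of the two numbers, a move towards a weaker inhibitor seems more likely than a further gain. The expected change in this assay is therefore upward and beyond the scatter, with the estimated step being an 8.9-fold higher number from compound 1 to compound 3 (0.95 log units; beyond the scatter). For compound 3 the estimated value is 80 nM, with an expected range from 20 nM to 400 nM.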

Compound 3, half-maximal inhibitory concentration: 76 nM
Beside the measured number, compound 3's estimate is 1.1-fold (0.02 log units) above it, and the stated range covers the measured number.
By their numbers in this assay, from the lowest: compound 1; then compounds 3 and 2 (each within the scatter of the next).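

In this assay the aromatic carbon two ring bonds from the ring nitrogen now has its first direct comparison: 2-chlorophenyl in place of 4-aminophenyl gives an 8.4-fold higher number from compound 1 to compound 3 (0.93 log units; beyond the scatter), so the group at this carbon is not interchangeable even when the heavy-atom count stays the same. The two groups share one six-membered aromatic ring of carbon only, but 4-aminophenyl has 1 hydrogen-bond donor and 1 hydrogen-bond acceptor, whereas 2-chlorophenyl has neither, and the substituent and its place on the phenyl ring change together. This single step therefore cannot separate the loss of the amine from the shift in substituent position, and nothing measured here accounts for the step.

The compounds shown leave open whether the amine itself or its place on the ring matters more, a question that 2-aminophenyl and 4-chlorophenyl at this carbon, each on the core of compound 1, would help to separate. They also leave open how an unsubstituted phenyl, a hydroxyl or a dimethylamino group would read at the same place.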